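Fluorophenyl change on the acyl urea of compound 1

This account rests on a few compounds, and the source may have more. Where it says the series, first, only, none or still open, it means among the compounds named here.

Measured so far in a functional assay on HeLa cells (Homo sapiens) for inhibition, read by MTT assay, with a stated time of 72 h; on this read-out higher numbers stand for weaker inhibition and lower numbers for stronger inhibition:
compound 1 `CN(C(=O)NC(=O)c1ccc(F)c(F)c1)c1nc(C(F)(F)F)c(C(=O)N/N=C/c2ccc(C(F)(F)F)cc2)s1`, 5.1 ug/mL
compound 2 `CN(C(=O)NC(=O)c1ccc(F)c(F)c1)c1nc(C(F)(F)F)c(C(=O)N/N=C/c2cccc(C(F)(F)F)c2)s1`, 4.21 ug/mL

Compound 1 gives the highest of the two numbers in this assay, and the nearest is compound 2, whose value lies within the scatter of it: the change a 1.2-fold lower number from compound 1 to compound 2 (0.08 log units; within the scatter), which moves the trifluoromethyl group on the benzylidene ring, leaves the read-out essentially unchanged.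

Compound 3 `CN(C(=O)NC(=O)c1ccccc1F)c1nc(C(F)(F)F)c(C(=O)N/N=C/c2ccc(C(F)(F)F)cc2)s1` is the next compound to be measured. It differs from compound 1 at the acyl end of the urea: 2-fluorophenyl in place of 3,4-difluorophenyl on a carbonyl carbon. This change is 2-fluorophenyl in place of 3,4-difluorophenyl on a carbonyl carbon whose other neighbour is an amide-type nitrogen.

Going by the values given here, no measured step touches this carbonyl-bound ring; the only step seen, from compound 1 to compound 2, concerns the other end of the molecule and was within the scatter. There is therefore no measured basis for a shift in either direction, and the expectation for compound 3 in this assay is a step of no change at the digits printed from compound 1 to compound 3 (within the scatter), that is none beyond the scatter. Compound 3 is estimated at 5.1 ug/mL, in the range 2.5 ug/mL to 10.5 ug/mL.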

Compound 3, half-maximal inhibitory concentration: 3.97 ug/mL
For compound 3 the middle estimate is 1.3-fold (0.11 log units) above the measured one; the range from low to high includes it.
By their numbers in this assay, from the lowest: compounds 3, 2 and 1 (each within the scatter of the next).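

In this assay, the carbonyl-bound ring now has a measured step of its own: 2-fluorophenyl in place of 3,4-difluorophenyl gives a 1.3-fold lower number from compound 1 to compound 3 (0.11 log units; within the scatter). At this position, on a carbonyl carbon whose other neighbour is an amide-type nitrogen, the read-out therefore does not separate a ring with two fluorines from one with a single fluorine at a different place, so both the number and the placement of fluorine differ without a result beyond the scatter. No evidence is available to explain this outcome.

The compounds shown leave open whether this insensitivity extends beyond fluorophenyl rings, as only those two rings occupy this position here, and unsubstituted phenyl, a ring carrying an amine or a carboxylic acid, or a saturated group such as cyclohexyl could still give a step beyond the scatter. On these data alone, compound 2 and compound 3 differ in two places, so they give no single-change reading, and how the two ends of the molecule act in combination also remains open.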